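The source may report more compounds than this note shows. Statements on the series, on what has been measured and on what is new or still open speak of the compounds shown alone.

Measured compounds in an assay on cells for inhibition of HSP60/HSP10 (Homo sapiens), with a stated time of 60 min; on this read-out higher numbers stand for weaker inhibition and lower numbers for stronger inhibition:

- Compound 1 `C=Cc1ccc(S(=O)(=O)Nc2ccc3oc(-c4ccccc4)nc3c2)cc1`: in this assay compound 1 gives > 100000 nM, which is a limit of the assay rather than a number.
- Compound 2 `O=S(=O)(Nc1ccc(-c2nc3ccccc3o2)cc1)c1ccc(F)c(C(F)(F)F)c1`: in this assay compound 2 gives 28000 nM.
- Compound 3 `O=S(=O)(Nc1ccc2oc(-c3ccccc3)nc2c1)c1ccc(F)c(C(F)(F)F)c1`: in this assay compound 3 gives 69000 nM.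

Compound 3 stands at the higher of the two numbers, so the weaker inhibition of the two; compound 2 sits at a lower number, and that gap is beyond the usual scatter. Compound 1 only reaches the limit (the limit of > 100000 nM in this assay, at which 1 of the 3 values shown sits), so it gives no number to place against the other two.

Compound 4 `O=S(=O)(Nc1ccc2oc(-c3ccccc3)nc2c1)c1ccc(Cl)c(C(F)(F)F)c1` is the next member of the series. It differs from compound 3 by chloro in place of fluoro on an aromatic carbon, ortho to a trifluoromethyl group and para to a large group.

Within the data shown here, no measured pair shows this exchange, so the direction is open. The expectation is a step of a 1.4-fold lower number from compound 3 to compound 4 (0.14 log units; within the scatter), no larger than the scatter, with a small shift toward a lower number as the more likely side. Compound 4 is therefore estimated at 50000 nM, with a range from 20000 nM to 150000 nM.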

Compound 4, half-maximal inhibitory concentration: > 100000 nM
Compound 4: only a limit was reported; the forecaster's own chance of this, stated with the estimate: 25%; middle value at least 2.0-fold (0.30 log units) from the limit.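

In this assay, among these compounds, chloro in place of fluoro, ortho to a trifluoromethyl group and para to a large group, gives the first step that can be read at this position: an at least 1.4-fold higher number from compound 3 to compound 4 (0.16 log units; that floor lies within the scatter). From the compounds shown here alone, compound 4 gives > 100000 nM, which is a limit of the assay and not a number, so the step is only a floor and its true size stays unknown. Compound 4 thus joins compound 1 at the same limit: the limit of > 100000 nM in this assay, at which 2 of the 4 values shown sit.

The compounds shown leave open how hydrogen, a methoxy group, a nitrile or an amine at this position would read. They also leave open whether the exchange of fluoro for chloro would read the same way on the core of compound 2, as this step comes from a single pair.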